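Replacing cyano with methylsulfonyl in compound 3

The source may hold more compounds than are shown below. What is called first, only, known or untested is meant among the compounds shown, and "the series" means these compounds.

In an ADME assay on microsomes from liver (Homo sapiens) for metabolic stability; a higher number here means that the compound lasts longer, a lower number that the compound disappears faster:
- compound 1 `CC1(C(=O)NCCSc2nonc2/C(=N/O)Nc2ccc(F)c(C(F)F)c2)CCN1` gives 1.97 h
- compound 2 `O=C(NCCSc1nonc1/C(=N/O)Nc1ccc(F)c(C(F)F)c1)C1CS(=O)(=O)C1` gives 1.28 h
- compound 3 `N#CCC(=O)NCCSc1nonc1/C(=N/O)Nc1ccc(F)c(C(F)F)c1` gives 2.77 h

Compound 3 stands clear of only one of the other two. The numbers show a 1.4-fold higher number from compound 1 to compound 3 (0.15 log units; within the scatter) and a 2.2-fold higher number from compound 2 to compound 3 (0.34 log units; beyond the scatter) and so only the second gap goes beyond the scatter.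

Compound 4 `CS(=O)(=O)CC(=O)NCCSc1nonc1/C(=N/O)Nc1ccc(F)c(C(F)F)c1` carries methylsulfonyl in place of cyano on a saturated chain carbon bound to a carbonyl carbon. Among the measured compounds shown here, no measured step makes this exact swap. The closest guide is compound 2, which also carries a sulfonyl group and gives 1.28 h in this assay, so a small fall is expected. The expected step is small and downward (a 1.5-fold lower number from compound 3 to compound 4 (0.16 log units; within the scatter)). Compound 4 is estimated at 1.9 h (expected range 1 h to 3.5 h).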

Compound 4, half-life: 1.27 h
Compound 4: middle estimate off by 1.5-fold (0.17 log units), on the high side; measured number inside the range.
By their numbers in this assay, from the lowest: compounds 4, 2, 1 and 3 (each within the scatter of the next, the first and the last beyond it).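

In this assay, methylsulfonyl in place of cyano at this position gives a drop that clears the scatter (a 2.2-fold lower number from compound 3 to compound 4 (0.34 log units; beyond the scatter)). With no ring, compound 4 still sits level with the ring-bearing sulfonyl compound (a 1.0-fold lower number from compound 2 to compound 4 (0.00 log units; within the scatter)) and within the scatter of the compound with the small nitrogen ring (a 1.6-fold lower number from compound 1 to compound 4 (0.19 log units; within the scatter)), so at this position the ring around the sulfonyl group makes no visible difference. No measurement here offers an explanation for the drop. As far as these compounds go, whether an amine, a carboxylic acid or a longer chain on this carbon would match compound 3 remains open.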